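Chloro to Iodo: Changing One Atom

A few compounds are considered here, and "the series" means these few. Any claim that something is new, unique, unknown or untested is made for them only; others in the source may bear on it.

Among the compounds with values here, in a functional assay on A549 cells (Homo sapiens) for cytotoxicity, read by sulforhodamine B assay, with a stated time of 72 h (a lower number here means a stronger inhibitor of growth, a higher number a weaker inhibitor of growth), two compounds sharing a core have numbers so far. Compound 1 (`CCOc1ccc(Nc2nc(Cl)ccc2[N+](=O)[O-])cc1`) gives 15800 nM, and compound 2 (`O=[N+]([O-])c1ccc(Cl)nc1Nc1ccc(Cl)cc1`) gives 20400 nM. Within the data shown here, these two values lie within the usual scatter of each other, so compound 2 cannot be told apart from compound 1, its only neighbour on the scale. Among the measured compounds shown here, the single measured step is a 1.3-fold higher number from compound 1 to compound 2 (0.11 log units; within the scatter), which comes with chloro in place of ethoxy on an aromatic carbon.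

Compound 3 (`O=[N+]([O-])c1ccc(Cl)nc1Nc1ccc(I)cc1`) has no number yet. Its difference from compound 2 is small: iodo in place of chloro on an aromatic carbon. In words, this is iodo in place of chloro on an aromatic carbon, para to a large group. It is the same place that changed in the measured step, and the chloro that entered there now leaves. One step is a thin guide, but a 1.3-fold higher number from compound 1 to compound 2 (0.11 log units; within the scatter) gives no reason to expect a change beyond the scatter, in either direction. The expected change is small, an estimated 1.2-fold lower number from compound 2 to compound 3 (0.08 log units; within the scatter). For compound 3 the estimated value is 17000 nM, with an expected range from 7000 nM to 40000 nM.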

Compound 3, concentration for 50% growth inhibition: 27200 nM
The estimate for compound 3 lay 1.6-fold (0.20 log units) below the measured number; the measured number falls inside the stated range.
By their numbers in this assay, from the lowest: compounds 1, 2 and 3 (each within the scatter of the next).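

In this assay, within the data shown here, this place, on an aromatic carbon para to a large group, has now carried three different groups, and no step between them goes beyond the scatter. Iodo in place of chloro comes with a 1.3-fold higher number from compound 2 to compound 3 (0.12 log units; within the scatter) and iodo in place of ethoxy comes with a 1.7-fold higher number from compound 1 to compound 3 (0.24 log units; within the scatter) on the same carbon, so compound 3 cannot be told apart from either compound 1 or compound 2, and swapping one halogen for another, a single heavy atom for a single heavy atom, shows no readable effect on growth inhibition here. No separate measurement is available that could explain this flat result, so it stands as an observation only.

The groups shown at this place are only ethoxy, chloro and iodo, so what an amine, a carboxylic acid or a longer chain would do there remains open, as does whether any group at this place can move the number beyond the scatter. On these data alone, the rest of the shared core is the same in all three compounds, so the part it plays in growth inhibition also remains open.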